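A few compounds are considered here, and "the series" means these few. Any claim that something is new, unique, unknown or untested is made for them only; others in the source may bear on it.

Measured in a functional assay on A549 cells (Homo sapiens) for antiproliferative activity, read by MTT assay, with a stated time of 72 h; a higher number here means a weaker inhibitor, a lower number a stronger inhibitor:
- compound 1 `CC(C)=CC(=O)Nc1cc2c(N3CCc4ccccc43)ncnc2cc1O[C@@H]1CCOC1`: 3670 nM
- compound 2 `CCC/C=C/C(=O)Nc1cc2c(N3CCc4ccccc43)ncnc2cc1O[C@@H]1CCOC1`: 9110 nM

Of these two, compound 2 has the higher number, 9110 nM, which makes it the weaker inhibitor. The two compounds share a core and differ only in the group on a carbonyl carbon. Replacing 2-methylprop-1-en-1-yl with pent-1-en-1-yl gives a 2.5-fold higher number from compound 1 to compound 2 (0.39 log units; beyond the scatter), a modest step beyond the usual scatter.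

Compound 3 `CN1CCN(C/C=C/C(=O)Nc2cc3c(N4CCc5ccccc54)ncnc3cc2O[C@@H]2CCOC2)CC1` keeps the core of compound 2 and alters the same side chain: 4-methylpiperazin-1-yl in place of ethyl on a saturated chain carbon bound to a double-bonded chain carbon. The change is 4-methylpiperazin-1-yl in place of ethyl, on a saturated chain carbon bound to a double-bonded chain carbon.

Among the compounds with values here, only that one measured step bears on this change, and it swapped one open chain for another, so it is a weak guide to a change that brings in a ring. It does show that this side chain can shift the number modestly. With compound 2 the higher of the pair, a modest move to a lower number seems more likely than a further rise, though neither is secure.

The estimated change is a 2.3-fold lower number from compound 2 to compound 3 (0.36 log units; beyond the scatter). Compound 3 is expected at 4000 nM, with an estimated range from 1000 nM to 12000 nM.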

Compound 3, half-maximal inhibitory concentration: 6090 nM
Beside the measured number, compound 3's estimate is 1.5-fold (0.18 log units) below it; the range from low to high includes it.
By their numbers in this assay, from the lowest: compounds 1, 3 and 2 (each within the scatter of the next, the first and the last beyond it).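

Swapping ethyl for 4-methylpiperazin-1-yl, on a saturated chain carbon bound to a double-bonded chain carbon, adds a six-membered non-aromatic ring with 2 hetero atoms, a far larger change than the earlier swap of one open chain for another. Even so, this assay records a 1.5-fold lower number from compound 2 to compound 3 (0.17 log units; within the scatter) for this change, so this position takes the ring without a shift that can be told apart from ordinary assay variation. Compound 3 is also not separated from the other compound, with a 1.7-fold higher number from compound 1 to compound 3 (0.22 log units; within the scatter) on the comparison of the full side chains, so it sits within the scatter of both, even though those two differ from each other by more than the scatter. Nothing measured here offers an explanation for this result.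

The compounds shown leave open whether a dimethylamino group or a morpholine ring at this same place would also leave the number within the scatter of compound 2. They also leave open whether a longer chain between the double bond and the piperazine ring would give a step beyond the scatter in either direction.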